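Removing the Ring Chlorine from a Benzoyl Ester Analogue

The source may report more compounds than this note shows. Statements on the series, on what has been measured and on what is new or still open speak of the compounds shown alone.

Of the compounds shown here, two sharing the same core have numbers so far. Compound 1, `O=C(/C(=C\c1c(-c2ccccc2)[nH]c2ccccc12)S(=O)(=O)c1ccccc1)c1ccccc1`, was tested in a functional assay on MT4 cells (Homo sapiens) for antiproliferative activity, read by MTT assay, with a stated time of 96 h (on this read-out lower numbers stand for an effect already at smaller amounts and higher numbers for an effect only at larger amounts of compound), where compound 1 gives 3000 nM. Compound 2, `CCOC(=O)/C(=C/c1c(-c2ccccc2)[nH]c2ccccc12)C(=O)c1ccc(Cl)cc1`, gives in this assay a value of 9000 nM. The two differ in more than one place, so only their values can be set side by side: compound 2 stands at the higher of the two numbers, and its gap to compound 1 lies beyond the usual scatter of repeated measurements.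

Compound 3, `CCOC(=O)/C(=C/c1c(-c2ccccc2)[nH]c2ccccc12)C(=O)c1ccccc1`, differs from compound 2 in a single place: hydrogen in place of chloro on an aromatic carbon, para to a large group. Among the compounds with values here, no measured pair in this set isolates such a change, so the size of the step has no direct precedent here. The step of a 1.3-fold lower number from compound 2 to compound 3 (0.11 log units; within the scatter) is expected to be modest and most likely within the scatter, if anything toward a somewhat lower number. In this assay compound 3 is therefore expected to give about 7000 nM, within a range from 3000 nM to 16000 nM.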

Compound 3, half-maximal effective concentration: 7000 nM
Estimate against measurement, compound 3: no gap at the digits printed; the measured number falls inside the stated range.
By their numbers in this assay, from the lowest: compound 1; then compounds 3 and 2 (each within the scatter of the next).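

In this assay, within the data shown here, the change from 4-chlorophenyl to phenyl gives a 1.3-fold lower number from compound 2 to compound 3 (0.11 log units; within the scatter) and is the first pair here to isolate a single change, showing that the chloro para to a large group can give way to hydrogen with no reading of a difference at this position. Compound 3 also links the two earlier compounds, which could previously be set side by side only by their values: ethoxycarbonyl in place of phenylsulfonyl, read in the opposite direction, corresponds to a 2.3-fold higher number from compound 1 to compound 3 (0.37 log units; beyond the scatter) and, unlike the loss of the chloro, lies beyond the scatter. Nothing available here accounts for either step.

The compounds shown leave open whether an amine, a methoxy group or a fluoro on the same aromatic carbon would read like hydrogen and chloro, since only these two groups have been compared at this place. They also leave open how a carboxylic acid or a longer chain in place of the ethyl ester would read, and whether a chloro on the benzoyl ring of compound 1 would give as small a step as it does on the ester.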